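The compounds below may be only part of what the source reports. "The series", "measured", "known", "first", "only" and "open" are said of these compounds alone.

Compound 1 `Cc1cc(C)cc(S(=O)(=O)c2c(C(=O)NCc3cccc(F)c3F)[nH]c3ccc(Cl)cc23)c1`, compound 2 `Cc1cc(C)cc(S(=O)(=O)c2c(C(=O)NCc3cccc(N)c3)[nH]c3ccc(Cl)cc23)c1` and compound 3 `Cc1cc(C)cc(S(=O)(=O)c2c(C(=O)NCC(=O)NC(C)c3ccncc3)[nH]c3ccc(Cl)cc23)c1` share one core and were all read in an ADME assay on MT4 cells (Homo sapiens) for cytotoxicity, read by MTT assay; a higher number here means that more compound is tolerated, a lower number that less compound is tolerated. In this assay compound 1 gives only a limit, > 51100 nM. In this assay compound 2 also gives only a limit, > 53400 nM. In this assay compound 3 gives 47000 nM. The step that the two limits leave unreadable from compound 1 to compound 2 cannot be read, while an at least 1.0-fold lower number from compound 1 to compound 3 (0.03 log units; that floor lies within the scatter) and an at least 1.1-fold lower number from compound 2 to compound 3 (0.05 log units; that floor lies within the scatter) stay within the scatter, so compound 2 stands at the ceiling of the assay, as the limit of > 53400 nM in this assay, at which 1 of the 3 values shown sits, and the limit of > 51100 nM in this assay, at which 1 of the 3 values shown sits, show. Compound 4 `Cc1cc(C)cc(S(=O)(=O)c2c(C(=O)NC(C)c3ccco3)[nH]c3ccc(Cl)cc23)c1` differs from compound 2 by 1-(furan-2-yl)ethyl in place of 3-aminobenzyl on an amide-type nitrogen. No measured step separates any two of these compounds beyond the scatter. Compound 4 is therefore expected to give 50000 nM, between 30000 nM and 80000 nM. The expected step is an at least 1.0-fold lower number from compound 2 to compound 4 (0.02 log units; that floor lies within the scatter), none beyond the scatter.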

Compound 4, half-maximal cytotoxic concentration: > 54700 nM
Compound 4: no number, only a limit; the forecaster's own chance of this, stated with the estimate: 65%; at least 1.0-fold (0.03 log units) between middle value and limit.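

In this assay compound 4 gives only a limit, so a five-membered aromatic ring in 1-(furan-2-yl)ethyl, on the amide-type nitrogen, also ends at the ceiling of the assay, as 3-aminobenzyl and 2,3-difluorobenzyl do: the limit of > 54700 nM in this assay, at which 1 of the 4 values shown sits. The data give an at least 1.1-fold higher number from compound 3 to compound 4 (0.06 log units; that floor lies within the scatter), and the steps to compound 4 from the two other limits cannot be read. From the compounds shown here alone, how far compound 1, compound 2 and compound 4 lie past their limits stays open, as does whether a carboxylic acid or a longer chain on this nitrogen would bring the number down.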